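The source may hold more compounds than are shown below. What is called first, only, known or untested is meant among the compounds shown, and "the series" means these compounds.

Compound 1 `CC(=O)N1CCN(S(=O)(=O)c2ccc(F)cc2)CC1` and compound 2 `CC(=O)N1CCN(S(=O)(=O)c2ccc(F)cc2)C(CO)C1` share a core that differs only in one saturated ring position. In a physicochemical assay for metabolic stability, read by LC-MS, in phosphate buffer, tested at 1 uM (a higher number here means that the compound lasts longer, a lower number that the compound disappears faster), compound 1 reaches the limit of the measurement and gives >= 4 h. In this assay compound 2 also reaches that limit and gives >= 4 h. The step that the two limits leave unreadable from compound 1 to compound 2 therefore cannot be sized, since both ends sit at the limit of >= 4 h in this assay, at which 2 of the 2 values shown sit. Compound 2 thus stands at the limit rather than at a number.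

Compound 3 `COCC1CN(C(C)=O)CCN1S(=O)(=O)c1ccc(F)cc1` differs from compound 2 by methyl in place of hydrogen on an oxygen on a saturated carbon, a methyl in place of hydrogen on an oxygen on a saturated carbon. Only the unreadable step from compound 1 to compound 2 bears on this change, and it says nothing about size or direction. Compound 3 is therefore expected to remain near the limit, an expected step that the limit leaves unreadable from compound 2 to compound 3. Compound 3 is estimated at 5 h, within a range of 2.5 h to 10 h.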

Compound 3, half-life: >= 4 h
Compound 3 gave a limit, no number; the forecaster's own chance of this, stated with the estimate: 70%; the middle value lies beyond the limit too.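

In this assay compound 3 gives only a limit, as compound 1 and compound 2 do, so no step among these compounds can be read: the limit of >= 4 h in this assay, at which 3 of the 3 values shown sit. The compounds shown leave open how long each one really lasts, and whether hydroxymethyl or methoxymethyl changes that at all.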